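A few compounds are considered here, and "the series" means these few. Any claim that something is new, unique, unknown or untested is made for them only; others in the source may bear on it.

- compound 1 `COc1ccc([C@@H]2C/C(=N/OCc3cn(-c4ccc(O)cc4)nn3)c3cc(CC=C(C)C)c(OC)cc3O2)cc1`: 52%
- compound 2 `COc1ccc([C@@H]2C/C(=N/OCc3cn(-c4ccc(Cl)cc4C)nn3)c3cc(CC=C(C)C)c(OC)cc3O2)cc1`: 35%
- compound 3 `COc1ccc([C@@H]2C/C(=N/OCc3cn(-c4ccccc4CO)nn3)c3cc(CC=C(C)C)c(OC)cc3O2)cc1`: 100%

In a functional assay on A549 cells (Homo sapiens) for inhibition, read by sulforhodamine B assay, with a stated time of 48 h, tested at 50 uM (a higher number here means more inhibition of growth at the concentration tested, a lower number less inhibition of growth), compound 1 gives 52% and stands second highest of the three, above compound 2 and below compound 3. Compound 4 `COc1ccc([C@@H]2C/C(=N/OCc3cn(-c4ccc(NC(=O)c5ccccc5)cc4)nn3)c3cc(CC=C(C)C)c(OC)cc3O2)cc1` is the next to read. Its change from the parent is benzamido in place of hydroxy on an aromatic carbon, with benzamido in place of hydroxy on an aromatic carbon, para to a large group.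

The measured steps that bear on it are swaps of the group on the aromatic nitrogen: a number 17 percentage points lower from compound 1 to compound 2 (beyond the scatter), which is modest, and a number 48 percentage points higher from compound 1 to compound 3 (beyond the scatter), which is large. The third, a number 65 percentage points higher from compound 2 to compound 3 (beyond the scatter), is also large. They point both ways, and none brings in a benzamido group, so the direction is a weak call. For the measured compounds named here, a modest step down in this assay is expected, resting on compound 2 at 35% as the one measured compound with neither hydroxy nor hydroxymethyl. The estimated change is a number 12 percentage points lower from compound 1 to compound 4 (beyond the scatter) in this series. For compound 4 the expected value is 40%, with an estimated range from 15% to 70% as the wide band.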

Compound 4, percent growth inhibition at one concentration: 31%
Beside the measured number, compound 4's estimate is 9 percentage points above it; low and high end bracket the measured number.
By their numbers in this assay, from the lowest: compounds 4 and 2 (each within the scatter of the next); then compound 1; then compound 3.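

In this assay, benzamido in place of hydroxy on the aromatic carbon, para to a large group, gives a number 21 percentage points lower from compound 1 to compound 4 (beyond the scatter). Unlike the earlier swaps of the whole group on the aromatic nitrogen, this step isolates one position on that group and shows that the read-out responds to a change there alone. The two groups have equal counts of hydrogen-bond donors and acceptors, so this step brings an added six-membered aromatic ring and a larger group without a change in those counts, and no measurement available here explains the loss.

An amine or a carboxylic acid at this position would show how smaller groups compare with hydroxy and benzamido. A phenyl or benzyloxy group would help separate the contribution of the added ring from that of the amide link.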